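Bis(arylidene)cyclohexanone series: cytotoxicity notes

This account rests on a few compounds, and the source may have more. Where it says the series, first, only, none or still open, it means among the compounds named here.

Measured compounds:
compound 1, `COc1cccc(/C=C2\CCC/C(=C\c3cccc(OC)c3OC)C2=O)c1` — 7000 nM
compound 2, `COc1ccc(/C=C2\CCC/C(=C\c3cccc(Cl)c3)C2=O)cc1OC` — 5100 nM

In a functional assay on SW-620 cells (Homo sapiens) for cytotoxicity, read by MTT assay, with a stated time of 72 h (a lower number here means a stronger inhibitor, a higher number a weaker inhibitor), compound 1 gives 7000 nM and compound 2 gives 5100 nM. Compound 2 holds the lowest of the two numbers recorded so far, but its gap to compound 1 lies within the scatter, so no order between the two can be read from these values.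

Compound 3, `COc1ccc(/C=C2\CCC/C(=C\c3ccc(O)c(O)c3)C2=O)cc1OC`, is not yet measured. It differs from compound 2 by one change: 3,4-dihydroxyphenyl in place of 3-chlorophenyl on a double-bonded chain carbon bound to a double-bonded ring carbon.

Going by the values given here, no step between measured compounds is recorded, so nothing here sets the size of this change. For compound 3 in this assay a modest step towards a lower number is expected, a 1.7-fold lower number from compound 2 to compound 3 (0.23 log units; within the scatter), though a result within the scatter of compound 2 would not surprise. The estimate for compound 3 in this assay is 3000 nM, with a range from 800 nM to 12000 nM.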

Compound 3, half-maximal inhibitory concentration: 10500 nM
Compound 3: middle estimate off by 3.5-fold (0.54 log units), on the low side; low and high end bracket the measured number.
By their numbers in this assay, from the lowest: compounds 2, 1 and 3 (each within the scatter of the next, the first and the last beyond it).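

In this assay, going by these compounds alone, 3,4-dihydroxyphenyl in place of 3-chlorophenyl on a double-bonded chain carbon bound to a double-bonded ring carbon gives a 2.1-fold higher number from compound 2 to compound 3 (0.31 log units; beyond the scatter), the first step that can be read. The aryl group at this place therefore changes the number, though the step is modest, and the exchange of a group without hydrogen-bond donors for one that carries them goes with weaker inhibition in this single pair. Nothing measured bears on the reason for this step.

On these data alone, whether the step follows the loss of the chlorine or the entry of the hydroxyl groups stays open, as this one exchange changes both at once. Unsubstituted phenyl at this place would help to separate the two, and a carboxylic acid or an amine on the same ring would show whether other groups bearing hydrogen-bond donors give a step of similar size.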